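The source may hold more compounds than are shown below. What is called first, only, known or untested is meant among the compounds shown, and "the series" means these compounds.

Compound 1 `CCCCCCCCCCCCn1nnc(C(NC(=O)c2ccc(OC)cc2)c2ccccc2)n1` gives 600 nM in an assay on microsomes from liver for inhibition of sterol O-acyltransferase 1 (Rattus norvegicus); on this read-out higher numbers stand for weaker inhibition and lower numbers for stronger inhibition; compound 2 `CCCCCCCCCCCCn1nnc(C(NC(=O)c2ccc(C)cc2)c2ccccc2)n1` gives 510 nM; compound 3 `CCCCCCCCCCCCn1nnnc1C(NC(=O)c1c(C)cccc1C)c1ccccc1` gives 180 nM.

Compound 3 gives the lowest number of the three, and its gaps to compound 2 and to compound 1 are both beyond the scatter. Compound 4 `CCCCCCCCCCCCn1nnnc1C(NC(=O)c1cccc([N+](=O)[O-])c1)c1ccccc1` has not yet been measured; it differs from compound 3 by 3-nitrophenyl in place of 2,6-dimethylphenyl on a carbonyl carbon. Within the data shown here, only one measured step exists, a 1.2-fold lower number from compound 1 to compound 2 (0.07 log units; within the scatter), and it swaps one small group for another on an otherwise unchanged ring, whereas compound 4 exchanges the whole 2,6-dimethylphenyl for 3-nitrophenyl, so that step hardly bears on it. Among the measured compounds shown here, with no close precedent, compound 4 is expected to give a higher number than compound 3, a 2.8-fold higher number from compound 3 to compound 4 (0.44 log units; beyond the scatter), estimated at 500 nM, with a range from 150 nM to 2000 nM.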

Compound 4, half-maximal inhibitory concentration: 190 nM
For compound 4 the middle estimate is 2.6-fold (0.42 log units) above the measured one; low and high end bracket the measured number.
By their numbers in this assay, from the lowest: compounds 3 and 4 (each within the scatter of the next); then compounds 2 and 1 (each within the scatter of the next).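

In this assay, the exchange on the carbonyl carbon gives a 1.1-fold higher number from compound 3 to compound 4 (0.02 log units; within the scatter), so the two compounds cannot be told apart. Among these compounds, the earlier step changed only one small group on a ring that stayed in place, whereas this one replaces the whole 2,6-dimethylphenyl with 3-nitrophenyl and the reading holds. No measurement on hand explains why these two different groups read alike. The compounds shown leave open how far this tolerance extends. A plain phenyl, a cyclohexyl or a group carrying a carboxylic acid at this place could still read quite differently.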